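The source may hold more compounds than are shown below. What is called first, only, known or untested is meant among the compounds shown, and "the series" means these compounds.

Measured so far:
- compound 1 `CCO/N=C/Nc1cc(Cl)c(SCC)c(Cl)c1` gives 4.6 in a physicochemical assay for lipophilicity, measured as octanol-water partition; a lower number here means a more polar compound, a higher number a more lipophilic compound
- compound 2 `CCO/N=C/Nc1cc(Cl)c(S(=O)(=O)CC)c(Cl)c1` gives 2.8 in this assay
- compound 3 `C#CCc1c(Cl)cc(N/C=N/OCC#N)cc1Cl` gives 3 in this assay

Compound 3 stands second highest of the three numbers. Its nearest neighbour is compound 2, which lies within the usual scatter of it, so no order between those two can be claimed; compound 1 lies well above it, beyond the scatter. Among the measured compounds shown here, the only step between measured compounds that differ in one place is a number 1.80 log units lower from compound 1 to compound 2 (beyond the scatter), a change at a sulfur atom on an aromatic carbon.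

Compound 4 `C#CCc1c(Cl)cc(N/C=N/Oc2ccc(C)cc2)cc1Cl` differs from compound 3 in one place: 4-methylphenyl in place of cyanomethyl on an oxygen

For the measured compounds named here, no measured step touches the group on this oxygen, so nothing measured bears directly on the change. The expectation rests only on the kind of exchange: a small chain carrying a nitrile leaves and an aromatic ring of seven carbons enters. For compound 4 a rise in this assay is expected, a step of about a number 2.00 log units higher from compound 3 to compound 4 (beyond the scatter), beyond the scatter. The estimate for compound 4 is 5, with a range from 4.3 to 5.7.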

Compound 4, partition coefficient: 4.8
Compound 4: the middle estimate sits 0.20 log units above what was measured; the range from low to high includes it.
By their numbers in this assay, from the lowest: compounds 2 and 3 (each within the scatter of the next); then compounds 1 and 4 (each within the scatter of the next).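

Among the compounds shown here, the group on this oxygen matters in this assay: 4-methylphenyl in place of cyanomethyl gives a number 1.80 log units higher from compound 3 to compound 4 (beyond the scatter), and no earlier step had touched this place. For the compounds shown here, the only earlier step, a number 1.80 log units lower from compound 1 to compound 2 (beyond the scatter), came from a change on an aromatic carbon, so a large shift in this read-out can now be tied to a second place in these compounds, an oxygen whose other neighbour is a double-bonded nitrogen. Nothing measured here explains the step.

This single exchange removes the nitrile and brings in the ring and its methyl all at once, so the compounds shown cannot divide the step among those parts. A plain phenyl without the methyl, a longer chain such as hexyl or a chain ending in a carboxylic acid on this same oxygen would help separate them.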